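The compounds below may be only part of what the source reports. "The series", "measured", "known", "first", "only" and "open" are said of these compounds alone.

The series shares one core, seen in compound 1 `COc1cc(OC)c(-c2nc3cc(/C=C4\SC(=O)NC4=O)ccc3[nH]2)cc1OC`, which in an ADME assay on HEK-293T cells (Homo sapiens) for inhibition, read by MTT assay, with a stated time of 48 h (a higher number here means a weaker inhibitor, a lower number a stronger inhibitor), gives 15300 nM. Compound 2 `COc1cc(-c2nc3cc(/C=C4\SC(=O)N(CC(=O)N5CCOCC5)C4=O)ccc3[nH]2)cc(OC)c1OC`, carrying the morpholine amide side chain and a 3,4,5-trimethoxyphenyl group, gives 18800 nM in this assay. Compound 3 `COc1ccc(-c2nc3cc(/C=C4\SC(=O)N(CC(=O)N5CCOCC5)C4=O)ccc3[nH]2)cc1OC` reaches only a limit of this assay, > 50000 nM, so for compound 3 only a range is known. The step of an at least 2.6-fold higher number from compound 2 to compound 3 (0.42 log units; beyond the scatter) carries the series to that limit, and the limit of > 50000 nM in this assay, at which 1 of the 3 values shown sits, is where compound 3 sits. Compound 4 `COc1cc(OC)c(-c2nc3cc(/C=C4\SC(=O)N(CC(=O)N5CCOCC5)C4=O)ccc3[nH]2)cc1OC` has not yet been measured. The change from compound 3 to compound 4 is methoxy in place of hydrogen on an aromatic carbon. Within the data shown here, the one measured step that bears on it is the step from compound 2 to compound 3, in which a methoxy left and the number rose beyond the scatter; here a methoxy enters again, though ortho to a large group, meta to a methoxy group and para to a methoxy group. Compound 1 and compound 2, each with three methoxy groups, show values close to one another in this assay. Compound 4 is therefore expected to move back from the limit by about an at least 2.5-fold lower number from compound 3 to compound 4 (0.39 log units; beyond the scatter). The estimate for compound 4 is 20000 nM, between 8000 nM and 60000 nM.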

Compound 4, half-maximal inhibitory concentration: 35700 nM
Compound 4: middle estimate off by 1.8-fold (0.25 log units), on the low side, and the stated range covers the measured number.
By their numbers in this assay, from the lowest: compounds 1, 2 and 4 (each within the scatter of the next, the first and the last beyond it). At a limit, above all of these: compound 3.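

With the morpholine amide side chain in place, the 2,4,5-trimethoxyphenyl and 3,4,5-trimethoxyphenyl groups are not separated in this assay: the step is a 1.9-fold higher number from compound 2 to compound 4 (0.28 log units; within the scatter). The methoxy entering ortho to a large group gives an at least 1.4-fold lower number from compound 3 to compound 4 (0.14 log units; that floor lies within the scatter), so this step alone does not show a change beyond the scatter. With the 2,4,5-trimethoxyphenyl group held fixed, ((morpholin-4-yl)carbonyl)methyl in place of hydrogen on the amide-type nitrogen gives a 2.3-fold higher number from compound 1 to compound 4 (0.37 log units; beyond the scatter), a modest step and the only one here that isolates this side chain on that group.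

On these data alone, compound 3 stands at a limit, so the full size of the steps that reach it stays unknown: the limit of > 50000 nM in this assay, at which 1 of the 4 values shown sits. Still open is how a hydroxyl or an ethoxy at this position would read in this assay, and how a piperazine amide or a carboxylic acid would read in place of the morpholine amide on the amide-type nitrogen.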